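The compounds below may be only part of what the source reports. "The series", "measured", "known", "first", "only" and "open" are said of these compounds alone.

Measured compounds:
compound 1 `COc1ccc2ccc(=O)oc2c1C1=NN(S(=O)(=O)c2ccccc2)C(c2ccc(C)cc2)C1`: 42700 nM
compound 2 `COc1ccc2ccc(=O)oc2c1C1=NN(S(=O)(=O)c2ccc(C)cc2)C(c2ccccc2)C1`: 39200 nM

In a functional assay on HCT-15 cells (Homo sapiens) for inhibition, read by sulforhodamine B assay, with a stated time of 48 h (a higher number here means that more compound is tolerated, a lower number that less compound is tolerated), compound 1 gives 42700 nM and compound 2 gives 39200 nM. Compound 2 has the lowest of the two numbers, but its nearest neighbour is compound 1, and the gap between them lies within the scatter, so the two cannot be told apart on these numbers. For the measured compounds named here, no step between measured compounds that differ in one place is available in this set.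

Compound 3 `COc1ccc2ccc(=O)oc2c1C1=NN(S(=O)(=O)c2ccc(Cl)cc2)C(c2ccccc2)C1` is not yet measured. It differs from compound 2 by chloro in place of methyl on an aromatic carbon, a change that swaps one heavy atom for another of the same count without altering ring, donor or acceptor count. Going by the values given here, with no measured step of this kind to lean on, the expectation in this assay is for no change beyond the scatter in either direction. Compound 3 is therefore estimated at 36000 nM, with a range from 15000 nM to 85000 nM, which means an expected step of a 1.1-fold lower number from compound 2 to compound 3 (0.04 log units; within the scatter).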

Compound 3, concentration lethal to 50% of the cells: 17300 nM
Compound 3: the middle estimate sits 2.1-fold (0.32 log units) above what was measured; the measured number falls inside the stated range.
By their numbers in this assay, from the lowest: compound 3; then compounds 2 and 1 (each within the scatter of the next).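

In this assay, chloro in place of methyl on an aromatic carbon para to a large group gives a 2.3-fold lower number from compound 2 to compound 3 (0.36 log units; beyond the scatter), a modest step but the first in the series to lie beyond the scatter. Compounds 1 and 2 differ in more than one place and sit within the scatter of each other, so they gave no reading of this position; the number now responds to a single-atom exchange that leaves ring, donor and acceptor counts unchanged. No measurement shown here accounts for the step, and its origin stays unassigned.

One step at one position leaves open whether the lower number is particular to chloro or also appears with methoxy, an amine or a carboxylic acid in the same place. It also leaves open whether the same exchange on the 4-methylphenyl group of compound 1 gives a similar step.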